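The source may hold more compounds than are shown below. What is called first, only, known or untested is meant among the compounds shown, and "the series" means these compounds.

Compound 2 `Cc1nnc(SCC(=O)N/N=c2/scc(-c3ccc(F)cc3)n2-c2ccccc2)s1` was tested in a functional assay on C6 cells (Rattus norvegicus) for cytotoxicity, read by MTT assay, with a stated time of 24 h (a lower number here means a stronger inhibitor, a higher number a weaker inhibitor), and gave 27.3 ug/mL. Among the three compounds measured it stands second highest. Its nearest neighbour is compound 3 `O=C(CSc1nnnn1-c1ccccc1)N/N=c1/scc(-c2ccc(F)cc2)n1-c1ccccc1`, which gave 24.3 ug/mL; the step of a 1.1-fold lower number from compound 2 to compound 3 (0.05 log units; within the scatter) is within the scatter. Furthest from it is compound 1 `O=C(CSc1ncccn1)N/N=c1/scc(-c2ccc(F)cc2)n1-c1ccccc1`, which gave 110 ug/mL; the step of a 4.0-fold lower number from compound 1 to compound 2 (0.61 log units; beyond the scatter) is modest but beyond the scatter, and compound 1 also stands apart from compound 3 by a 4.5-fold lower number from compound 1 to compound 3 (0.66 log units; beyond the scatter).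

Compound 4 `Cc1nnc(SCC(=O)N/N=c2/scc(-c3ccccc3)n2-c2ccccc2)s1` differs from compound 2 at a single place: hydrogen in place of fluoro on an aromatic carbon. Among the measured compounds shown here, none of the measured steps bears on this change; each of them alters the group on the sulfur, and every measured compound carries the same 4-fluorophenyl. Without a measured step at this position, the expectation is a step no larger than the scatter, in either direction. Compound 4 is therefore estimated at 30 ug/mL, within 14 ug/mL to 65 ug/mL, which means an expected step of a 1.1-fold higher number from compound 2 to compound 4 (0.04 log units; within the scatter).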

Compound 4, half-maximal inhibitory concentration: > 200 ug/mL
Compound 4 ended at the assay's limit; the forecaster's own chance of this, stated with the estimate: 5%; middle value at least 6.6-fold (0.82 log units) away from the limit.
By their numbers in this assay, from the lowest: compounds 3 and 2 (each within the scatter of the next); then compound 1. At a limit, above all of these: compound 4.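

In this assay compound 4 gives > 200 ug/mL, which is a limit of the assay and not a number: the limit of > 200 ug/mL in this assay, at which 1 of the 4 values shown sits. The earlier compounds shown here all carried the 4-fluorophenyl and differed only in the group on the sulfur, so they said nothing about this position. Now the change from 4-fluorophenyl to phenyl gives an at least 7.3-fold higher number from compound 2 to compound 4 (0.86 log units; beyond the scatter), so with 5-methyl-1,3,4-thiadiazol-2-yl on the sulfur, the single fluoro on this aromatic carbon moves the number at least as far as the changes on the sulfur, such as a 4.5-fold lower number from compound 1 to compound 3 (0.66 log units; beyond the scatter).

As far as these compounds go, whether chloro, methoxy or an amine in place of fluoro on this carbon would keep the number close to that of compound 2 stays open. Also open, from the compounds shown here alone, is whether hydrogen in place of fluoro has the same outcome with pyrimidin-2-yl or 1-phenyl-1H-tetrazol-5-yl on the sulfur.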